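Methyl to fluoro swap on compound 3

This account rests on a few compounds, and the source may have more. Where it says the series, first, only, none or still open, it means among the compounds named here.

In an ADME assay on SH-SY5Y cells (Homo sapiens) for cytotoxicity, read by MTT assay, with a stated time of 72 h (on this read-out higher numbers stand for weaker inhibition and lower numbers for stronger inhibition), compound 3 (`Cc1ccc(C(=O)N2CCN(CC(=O)N3CCN(CCCc4c[nH]c5ccc(F)cc45)CC3)CC2)cc1`) gives 119000 nM and sits within the scatter of compound 1 (`O=C(CN1CCN(C(=O)c2ccccc2)CC1)N1CCN(CCCc2c[nH]c3ccc(F)cc23)CC1`) at 146000 nM but higher than compound 2 (`O=C(CN1CCN(C(=O)c2ccc(Br)cc2)CC1)N1CCN(CCCc2c[nH]c3ccc(F)cc23)CC1`) at 47400 nM on these numbers. Compound 4 (`O=C(CN1CCN(C(=O)c2ccc(F)cc2)CC1)N1CCN(CCCc2c[nH]c3ccc(F)cc23)CC1`) differs by fluoro in place of methyl on an aromatic carbon on an aromatic carbon, para to a large group. Within the data shown here, three measured steps bear on this: a 1.2-fold lower number from compound 1 to compound 3 (0.09 log units; within the scatter) for methyl in place of hydrogen, a 3.1-fold lower number from compound 1 to compound 2 (0.49 log units; beyond the scatter) for bromo in place of hydrogen and a 2.5-fold higher number from compound 2 to compound 3 (0.40 log units; beyond the scatter) for methyl in place of bromo. Among the measured compounds shown here, only the steps involving compound 2 exceed the scatter, and none involves fluoro. An expected 1.2-fold lower number from compound 3 to compound 4 (0.08 log units; within the scatter) therefore means no move beyond the scatter in this assay is anticipated. For compound 4 the estimate is 100000 nM with an expected range of 50000 nM to 190000 nM in this read-out.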

Compound 4, half-maximal inhibitory concentration: 121000 nM
The estimate for compound 4 lay 1.2-fold (0.08 log units) below the measured number; the range from low to high includes it.
By their numbers in this assay, from the lowest: compound 2; then compounds 3, 4 and 1 (each within the scatter of the next).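

In this assay fluoro at this position reads like methyl, with a 1.0-fold higher number from compound 3 to compound 4 (0.01 log units; within the scatter) and like hydrogen, with a 1.2-fold lower number from compound 1 to compound 4 (0.08 log units; within the scatter) in the same setting. Only bromo stands apart, with a 2.6-fold higher number from compound 2 to compound 4 (0.41 log units; beyond the scatter) so the separation among these four compounds rests on compound 2 alone. No measured data here account for that separation.

Open, on these data alone, is whether chloro, trifluoromethyl, an amine or a carboxylic acid in this place would group with bromo or with the other three. Also open, as far as these compounds go, is whether the bromo step would hold with any other change to the shared core.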